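Opening the lactone ring of an acetylated quinone derivative

The source may hold more compounds than are shown below. What is called first, only, known or untested is meant among the compounds shown, and "the series" means these compounds.

Compound 1, `COC1=C(OC)[C@H](O)[C@H](C/C=C(\C)CC/C=C(\C)C[C@@H]2C[C@@H](C)C(=O)O2)[C@@H](C)C1=O`, in a functional assay on A549 cells (Homo sapiens) for inhibition, read by sulforhodamine B assay, with a stated time of 48 h (a lower number here means a stronger inhibitor of growth, a higher number a weaker inhibitor of growth), gives 14100 nM.
Compound 2, `COC1=C(OC)[C@H](O)[C@H](C/C=C(\C)CC/C=C(\C)CCCC(C)CO)[C@@H](C)C1=O`, gives 7100 nM.
Compound 3, `COC1=C(OC)[C@H](OC(C)=O)[C@H](C/C=C(\C)CC/C=C(\C)C[C@@H]2C[C@@H](C)C(=O)O2)[C@@H](C)C1=O`, gives 11300 nM.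

Compound 3 sits close to both of its companions. Its step from compound 1 is a 1.2-fold lower number from compound 1 to compound 3 (0.10 log units; within the scatter), and against compound 2 the two values likewise lie within the usual spread of repeated measurements, so none of the three can be set apart from the others.

Compound 4, `COC1=C(OC)[C@H](OC(C)=O)[C@H](C/C=C(\C)CC/C=C(\C)C[C@H](O)/C=C(\C)C(=O)O)[C@@H](C)C1=O`, differs from compound 3 in one place: a group of 8 heavy atoms (5 carbon, 3 oxygen; no ring) in place of a group of 7 heavy atoms (5 carbon, 2 oxygen; one five-membered non-aromatic ring with 1 hetero atom), on a saturated chain carbon bound to a double-bonded chain carbon. Going by the values given here, the measured step that speaks to this change is the one from compound 1 to compound 2, in which the same five-membered ring at the same place gave way to an open chain: a 2.0-fold lower number from compound 1 to compound 2 (0.30 log units; within the scatter). That precedent shows no movement beyond the scatter, and nothing else in the data points another way.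

The expected step is therefore a 1.2-fold lower number from compound 3 to compound 4 (0.08 log units; within the scatter), nothing beyond the scatter. Compound 4 is estimated at 9500 nM, with a range from 3000 nM to 30000 nM.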

Compound 4, concentration for 50% growth inhibition: > 30000 nM
Compound 4 ended at the assay's limit; the forecaster's own chance of this, stated with the estimate: 5%; middle value at least 3.1-fold (0.49 log units) away from the limit.
By their numbers in this assay, from the lowest: compounds 2, 3 and 1 (each within the scatter of the next). At a limit, above all of these: compound 4.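

Opening the five-membered ring at this saturated chain carbon bound to a double-bonded chain carbon is not always neutral in this assay: the new open chain gives an at least 2.6-fold higher number from compound 3 to compound 4 (0.42 log units; beyond the scatter), whereas the earlier one gave a 2.0-fold lower number from compound 1 to compound 2 (0.30 log units; within the scatter). The value of compound 4 is a limit of the assay and not a number: the limit of > 30000 nM in this assay, at which 1 of the 4 values shown sits. The two open chains therefore do not behave alike at this place, although their steps start from different compounds, one with a free hydroxyl on the saturated carbon of the core and the other with an acetyl on that oxygen.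

The compounds shown leave open which part of the entering group accounts for the step. A methyl ester or an amide at the chain end would test this, as would the same chain on the core of compound 1.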